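Acid to Benzylamide: An Open Step

The compounds below may be only part of what the source reports. "The series", "measured", "known", "first", "only" and "open" are said of these compounds alone.

Measured so far:
compound 1 `COc1cc2c(cc1O)C(=O)CC(C(=O)O)O2` — 105000 nM
compound 2 `COc1cc2c(cc1O)CCC(C(=O)O)O2` — 16800 nM

In a functional assay on the whole organism for inhibition, with Rattus norvegicus as the target (on this read-out higher numbers stand for weaker inhibition and lower numbers for stronger inhibition), compound 1 gives 105000 nM, the higher of the two numbers shown, while compound 2 gives 16800 nM, a gap that lies beyond the scatter. Compound 3 `COc1cc2c(cc1O)C(=O)CC(C(=O)NCc1ccccc1)O2` has not yet been measured; it differs from compound 1 by benzylamino in place of hydroxy on a carbonyl carbon. Among the measured compounds shown here, no measured pair shows this change, so the size of the step is unknown. A modest gain in inhibition is expected, a 2.6-fold lower number from compound 1 to compound 3 (0.42 log units; beyond the scatter), though a step within the scatter cannot be ruled out. Compound 3 is estimated at 40000 nM, between 8000 nM and 150000 nM.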

Compound 3, half-maximal inhibitory concentration: 119000 nM
Compound 3: middle estimate off by 3.0-fold (0.47 log units), on the low side; low and high end bracket the measured number.
By their numbers in this assay, from the lowest: compound 2; then compounds 1 and 3 (each within the scatter of the next).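

In this assay, benzylamino in place of hydroxy on a carbonyl carbon gives a 1.1-fold higher number from compound 1 to compound 3 (0.05 log units; within the scatter) and so leaves the read-out within the scatter, even though the change adds a six-membered aromatic ring of carbon only. On the core of compound 1, the carboxylic acid and the benzylamide therefore cannot be told apart on this read-out. Nothing available explains this result.

Still open, as far as these compounds go, is whether methylamino or a longer chain such as phenethylamino on the same carbonyl carbon would read differently. Also open, from the compounds shown here alone, is whether benzylamino would give the same step on the core of compound 2.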